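A few compounds are considered here, and "the series" means these few. Any claim that something is new, unique, unknown or untested is made for them only; others in the source may bear on it.

Measured so far:
- compound 1, `Cc1ccccc1CN1CCc2c(sc(NC(=O)c3ccccc3Cl)c2C(N)=O)C1`: in a functional assay on MKN-74 cells (Homo sapiens) for antiproliferative activity, with a stated time of 24 h (a higher number here means a weaker inhibitor, a lower number a stronger inhibitor), compound 1 gives > 50000 nM, which is a limit of the assay and not a number.
- compound 2, `NC(=O)c1c(NC(=O)c2ccccc2)sc2c1CCN(C(=S)Nc1ccccc1Cl)C2`: in this assay compound 2 gives 11800 nM.

Going by the values given here, compound 2 thus holds the only number so far in this assay; the one other value is a limit, (the limit of > 50000 nM in this assay, at which 1 of the 2 values shown sits). Among the compounds with values here, no step between measured compounds is available, so nothing measured bears on a change of this kind.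

Compound 3, `NC(=O)c1c(NC(=O)c2ccc(C(F)(F)F)cc2)sc2c1CCN(C(=S)Nc1ccccc1Cl)C2`, differs from compound 2 by trifluoromethyl in place of hydrogen on an aromatic carbon, in words trifluoromethyl in place of hydrogen on an aromatic carbon. Without a measured step to lean on, the expected step from compound 2 to compound 3 in this assay is set small, a 1.5-fold lower number from compound 2 to compound 3 (0.17 log units; within the scatter), not clearly beyond the scatter in either direction. Compound 3 is therefore estimated at 8000 nM, with a range from 2500 nM to 30000 nM.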

Compound 3, half-maximal inhibitory concentration: 16400 nM
Compound 3: middle estimate off by 2.1-fold (0.31 log units), on the low side; the measured number falls inside the stated range.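

The series now has its first readable step: in this assay, trifluoromethyl in place of hydrogen on an aromatic carbon gives a 1.4-fold higher number from compound 2 to compound 3 (0.14 log units; within the scatter). For this one pair, the change from phenyl to 4-(trifluoromethyl)phenyl, with 4 heavy atoms entering at a place para to a large group, cannot be told from the scatter, so this position takes the larger group with no measurable shift in the read-out. Nothing measured here bears on a cause for this step.

As far as these compounds go, whether an amine, a carboxylic acid or a longer chain at the same place would move the number beyond the scatter remains open. From the compounds shown here alone, compound 1 and compound 2 differ in more than one place, so what separates them also remains open.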